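Swapping Chloro for Iodo on the Phenyl Sulfide Arm

The source may hold more compounds than are shown below. What is called first, only, known or untested is meant among the compounds shown, and "the series" means these compounds.

Compound 1 `OC[C@H]1O[C@@H](n2cnc3c(CSc4ccccc4Cl)ncnc32)[C@H](O)[C@@H]1O` carries a chlorophenyl sulfide arm on the shared core, and in an assay on isolated protein for binding affinity to Equilibrative nucleoside transporter 1 (Homo sapiens) (a higher number here means a weaker inhibitor, a lower number a stronger inhibitor), compound 1 gives 1780 nM. Compound 2 `OC[C@H]1O[C@@H](n2cnc3c(CSc4ccccc4I)ncnc32)[C@H](O)[C@@H]1O` differs from compound 1 by iodo in place of chloro on an aromatic carbon, and in this assay compound 2 gives 282 nM, so that a 6.3-fold lower number from compound 1 to compound 2 (0.80 log units; beyond the scatter). Compound 3 `OC[C@H]1O[C@@H](n2cnc3c(CSc4cccc(Cl)c4)ncnc32)[C@H](O)[C@@H]1O` differs from compound 1 by 3-chlorophenyl in place of 2-chlorophenyl on a sulfur, and in this assay compound 3 gives 282 nM, a 6.3-fold lower number from compound 1 to compound 3 (0.80 log units; beyond the scatter). Between the two, no change at the digits printed from compound 2 to compound 3 (within the scatter). Compound 4 `OC[C@H]1O[C@@H](n2cnc3c(CSc4cccc(I)c4)ncnc32)[C@H](O)[C@@H]1O` is not yet measured and differs from compound 3 by iodo in place of chloro on an aromatic carbon. This is the same kind of change as from compound 1 to compound 2, but in compound 1 the place is ortho to a large group, whereas in compound 3 it is meta to a large group. A smaller step is expected, a 2.6-fold lower number from compound 3 to compound 4 (0.41 log units; beyond the scatter), resting on compound 3 already giving 282 nM, the lower of the two levels seen. In this assay compound 4 is expected to give 110 nM, between 35 nM and 350 nM.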

Compound 4, half-maximal inhibitory concentration: 245 nM
Compound 4: middle estimate off by 2.2-fold (0.35 log units), on the low side; low and high end bracket the measured number.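

On the 3-chlorophenyl arm, iodo in place of chloro gives a 1.2-fold lower number from compound 3 to compound 4 (0.06 log units; within the scatter), and 3-iodophenyl in place of 2-iodophenyl gives a 1.2-fold lower number from compound 2 to compound 4 (0.06 log units; within the scatter), while 3-iodophenyl in place of 2-chlorophenyl gives a 7.3-fold lower number from compound 1 to compound 4 (0.86 log units; beyond the scatter). So in this assay the swap of chloro for iodo does not keep its size from one core to the other: the same change on two cores in this assay, a 6.3-fold lower number (0.80 log units; beyond the scatter) from compound 1 to compound 2 and a 1.2-fold lower number (0.06 log units; within the scatter) from compound 3 to compound 4, 5.5-fold (0.74 log units) apart, beyond the scatter of two such steps These two pairs show that a gain seen on one arm cannot simply be assumed on another, but they give neither a reason for the difference nor a rule for further arms.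

Still open, going by these compounds, is how other groups would read at the same place on the phenyl ring, such as bromo, methyl, an amine or a carboxylic acid.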